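The source may hold more compounds than are shown below. What is called first, only, known or untested is meant among the compounds shown, and "the series" means these compounds.

Three compounds share one core and differ only in the group on the far phenyl ring. In a toxicity assay on WI-38 cells (Homo sapiens) for cytotoxicity, read by MTT assay, with a stated time of 48 h (a lower number here means a stronger inhibitor, a higher number a weaker inhibitor), compound 1, `O=C(/C=C/c1ccc2c(c1)B(O)OC2)c1ccccc1`, gives 19100 nM. Compound 2, `O=C(/C=C/c1ccc2c(c1)B(O)OC2)c1ccc(I)cc1`, reaches only a limit of this assay, > 100000 nM. Compound 3, `CCc1ccc(C(=O)/C=C/c2ccc3c(c2)B(O)OC3)cc1`, gives 20600 nM in this assay. The step of an at least 5.2-fold higher number from compound 1 to compound 2 (0.71 log units; beyond the scatter) is beyond the scatter, whereas a 1.1-fold higher number from compound 1 to compound 3 (0.03 log units; within the scatter) stays within it, and an at least 4.8-fold lower number from compound 2 to compound 3 (0.68 log units; beyond the scatter) again lies beyond it. Among the two plain numbers compound 3 holds the higher one, though its gap to compound 1 is within the scatter; the third value is a limit (the limit of > 100000 nM in this assay, at which 1 of the 3 values shown sits).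

Compound 4, `CSc1ccc(C(=O)/C=C/c2ccc3c(c2)B(O)OC3)cc1`, has not yet been measured. Its difference from compound 3 is methylsulfanyl in place of ethyl on an aromatic carbon. Among the compounds with values here, no measured step swaps in a methylsulfanyl group, so the nearest guidance comes from the steps around the ethyl group: a 1.1-fold higher number from compound 1 to compound 3 (0.03 log units; within the scatter) shows that adding ethyl to hydrogen hardly moved this assay, while an at least 4.8-fold lower number from compound 2 to compound 3 (0.68 log units; beyond the scatter) shows that the iodo group stands apart. Exchanging one small, uncharged two-atom group for another is therefore expected to give a step of about a 1.2-fold higher number from compound 3 to compound 4 (0.08 log units; within the scatter), which is within the scatter. The value expected for compound 4 in this assay is 25000 nM, within a range from 10000 nM to 70000 nM.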

Compound 4, half-maximal inhibitory concentration: 54300 nM
Compound 4: middle estimate off by 2.2-fold (0.34 log units), on the low side, within the range that was stated.
By their numbers in this assay, from the lowest: compounds 1 and 3 (each within the scatter of the next); then compound 4. At a limit, above all of these: compound 2.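

The position on the far phenyl ring, para to a large group, is not indifferent to what sits there, even though ethyl and hydrogen could not be told apart. In this assay the exchange of ethyl for methylsulfanyl gives a 2.6-fold higher number from compound 3 to compound 4 (0.42 log units; beyond the scatter) even though both groups have 2 heavy atoms, so the heavy-atom count alone does not set the number here, and methylsulfanyl, with its sulfur and its hydrogen-bond acceptor, also stands apart from hydrogen, with a 2.8-fold higher number from compound 1 to compound 4 (0.45 log units; beyond the scatter) as the step. Compound 4 now lies above compounds 1 and 3, but it cannot be firmly separated from the iodo compound, since an at least 1.8-fold lower number from compound 2 to compound 4 (0.26 log units; that floor lies within the scatter) is only a floor and compound 2 gives a limit rather than a number: the limit of > 100000 nM in this assay, at which 1 of the 4 values shown sits.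

As far as these compounds go, whether the rise follows the sulfur atom or the acceptor count remains open, and a methoxy group or an amine at this place would help to separate the two. A longer chain, such as propyl, could likewise show whether the ethyl result holds beyond a group of that length.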